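Chloro in place of bromo: compound 3 to compound 4

The compounds below may be only part of what the source reports. "The series", "measured", "known", "first", "only" and "open" are said of these compounds alone.

Three compounds carry numbers in an in vitro assay on 293-EBNA cells for binding affinity to corticotropin-releasing factor receptor 1 (Homo sapiens); a higher number here means a weaker inhibitor, a lower number a stronger inhibitor. Compound 1, `CCCCN(CC)c1nc(C)nc2c1nnn2-c1c(C)cc(C)cc1C`, gives 27.5 nM in this assay. Compound 2, `CCCCN(CC)c1nc(C)nc2c1nnn2-c1c(C)cc(C)nc1C`, gives 65 nM. Compound 3, `CCCCN(CC)c1nc(C)nc2c1ncn2-c1c(Br)cc(OC)cc1OC`, gives 3.5 nM and thus has the lowest number of the three; the nearest is compound 1 and the furthest compound 2, and both gaps lie beyond the usual scatter. Compound 4, `CCCCN(CC)c1nc(C)nc2c1ncn2-c1c(Cl)cc(OC)cc1OC`, has not yet been measured. It differs from compound 3 in one place: chloro in place of bromo on an aromatic carbon. Within the data shown here, no pair of measured compounds differs by this same change, so there is nothing against which the size of the step can be read. With the rest of the molecule unchanged, the number for compound 4 is expected to stay close to that of compound 3, with no step beyond the usual scatter and no preference for either direction. For compound 4 the estimate in this assay is 4.5 nM, between 2 nM and 10 nM. The expected step is a 1.3-fold higher number from compound 3 to compound 4 (0.11 log units; within the scatter), essentially flat.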

Compound 4, inhibition constant: 5.2 nM
Beside the measured number, compound 4's estimate is 1.2-fold (0.06 log units) below it; measured number inside the range.
By their numbers in this assay, from the lowest: compounds 3 and 4 (each within the scatter of the next); then compound 1; then compound 2.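

In this assay, among these compounds, a 1.5-fold higher number from compound 3 to compound 4 (0.17 log units; within the scatter) gives the first comparison between compounds that differ in one place, and its size stays within the scatter. At this aromatic carbon, ortho to a large group and meta to two methoxy groups, chloro and bromo therefore cannot be told apart by this read-out, and affinity does not depend on bromo specifically among these two halogens. The earlier compounds could not show this, since no two of them differed in one place only, and nothing measured here accounts for the flat step.

Going by these compounds, whether the same position also accepts fluoro, iodo, a nitrile or a longer chain such as ethyl, with the rest of compound 3 unchanged, remains open, and with it how far this tolerance extends beyond two halogens. Among the compounds shown here, also open is whether the chloro-for-bromo change would stay this small with the two methoxy groups replaced, for instance by hydroxy groups, since only one setting for this change is available so far.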